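Working notes: aryl replacement on compound 3

The compounds below may be only part of what the source reports. "The series", "measured", "known", "first", "only" and "open" are said of these compounds alone.

Measured compounds in a functional assay on HT-1080 cells (Homo sapiens) for antiproliferative activity, read by MTT assay, with a stated time of 72 h; on this read-out higher numbers stand for weaker inhibition and lower numbers for stronger inhibition:
compound 1 `COc1ccc(-c2cc3[nH]nc(-c4cc(OC)c(OC)c(OC)c4)n3n2)cc1` gives 26500 nM
compound 2 `COc1ccc(-c2cc3[nH]nc(-c4cc(OC)c(OC)c(OC)c4)n3n2)cc1[N+](=O)[O-]` gives 35600 nM
compound 3 `COc1ccc(-c2nnc3sc(-c4ccc(C)cc4)nn23)c(OC)c1OC` gives 89 nM

Compound 3 has the lowest number of the three. Going by the values given here, its nearest neighbour is compound 1, whose value is far higher, and compound 2 is further still; no direct single-point step joins compound 3 to either, so only the two values themselves speak, and the gap is well beyond the scatter. Compound 3 thus stands alone as the potent member of this set.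

Compound 4 `COc1ccc(-c2nn3c(-c4ccc(OC)c(OC)c4OC)nnc3s2)cc1N` is not yet measured. The change from compound 3 is 3-amino-4-methoxyphenyl in place of 4-methylphenyl on an aromatic carbon. Among the compounds with values here, the only measured step that touches the same kind of change is the one from compound 1 to compound 2, a substitution on the aryl ring of a different core: a 1.3-fold higher number from compound 1 to compound 2 (0.13 log units; within the scatter). That step is small, but it concerns a nitro group on another scaffold, so it bears only loosely on the present change. The expectation is therefore a modest shift, with the direction uncertain, of about a 1.7-fold higher number from compound 3 to compound 4 (0.23 log units; within the scatter). On that basis compound 4 is estimated at 150 nM, with a range from 40 nM to 600 nM.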

Compound 4, half-maximal inhibitory concentration: 73 nM
Compound 4: middle estimate off by 2.1-fold (0.31 log units), on the high side; measured number inside the range.
By their numbers in this assay, from the lowest: compounds 4 and 3 (each within the scatter of the next); then compounds 1 and 2 (each within the scatter of the next).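

Working notes, continued: at the aromatic carbon of the five-membered aromatic ring with 2 nitrogen and 1 sulfur, this assay gives a 1.2-fold lower number from compound 3 to compound 4 (0.09 log units; within the scatter) for 3-amino-4-methoxyphenyl in place of 4-methylphenyl. This position therefore tolerates a larger aryl group carrying a hydrogen-bond donor and acceptors, with no change beyond the scatter, and potency is kept on this core. The earlier step, a 1.3-fold higher number from compound 1 to compound 2 (0.13 log units; within the scatter) on a different core, could not show this, and no supporting data on the cause are at hand.

Compound 4 differs from compound 3 by the amine and the methoxy together, so the share of each group stays unresolved. On these data alone, whether a carboxylic acid or a longer chain on this aryl ring would hold the value also remains open.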